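A few compounds are considered here, and "the series" means these few. Any claim that something is new, unique, unknown or untested is made for them only; others in the source may bear on it.

Compound 1 `C[C@@]1(O)[C@H](O)[C@@H](CO)O[C@H]1c1ccc2c(N)ncnn12`: > 100000 nM
Compound 2 `C[C@@]1(O)[C@H](O)[C@@H](CO)O[C@H]1c1cnc2c(N)ncnn12`: 26000 nM

Both compounds were run in an ADME assay on Huh-7 cells (Homo sapiens) for cytotoxicity; a lower number here means that less compound is tolerated, a higher number that more compound is tolerated. Compound 1 stands at > 100000 nM, which is a limit of the assay and not a number. For the measured compounds named here, compound 2, at 26000 nM, holds the only true number so far, so it is the sole numerical anchor for what follows.

Compound 3 `C[C@@]1(O)[C@H](O)[C@@H](CO)O[C@H]1c1cnc2c(N)nc(F)nn12` keeps the core of compound 2 and carries fluoro in place of hydrogen on an aromatic carbon, on the six-membered aromatic ring with 3 nitrogen, between two ring nitrogen atoms (fluoro in place of hydrogen on an aromatic carbon). Going by the values given here, no measured pair shows what this change does in this assay, so any expectation is loose. A modest move towards less compound being tolerated is expected, starting from compound 2 at 26000 nM, with no change beyond the scatter still a real possibility. The expected step is a 2.2-fold lower number from compound 2 to compound 3 (0.34 log units; beyond the scatter). For compound 3 the estimate is 12000 nM, with an expected range of 2500 nM to 60000 nM.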

Compound 3, half-maximal cytotoxic concentration: > 100000 nM
Compound 3 gave a limit, no number; the forecaster's own chance of this, stated with the estimate: 15%; middle value at least 8.3-fold (0.92 log units) from the limit.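

In this assay, fluoro in place of hydrogen on an aromatic carbon, at the position between two ring nitrogen atoms, gives an at least 3.8-fold higher number from compound 2 to compound 3 (0.58 log units; beyond the scatter), so at this position the change moves the read-out towards more compound being tolerated. For the compounds shown here, this is the first step that can be read for a change in one place, and it gives compound 2 a direct comparison for the first time. The full size of the step cannot be read because compound 3 stands at a limit of the assay, not at a number: the limit of > 100000 nM in this assay, at which 2 of the 3 values shown sit.

The compounds shown give a single replacement at this position on a single core, so they cannot tell whether the step is specific to fluoro or would also follow from other replacements of hydrogen there. Going by these compounds, how chloro, a methyl group or a nitrile at the same position would read in this assay remains open, as does whether fluoro would have any readable effect on the core of compound 1.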